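This account rests on a few compounds, and the source may have more. Where it says the series, first, only, none or still open, it means among the compounds named here.

Measured so far in a functional assay on CHO cells for antagonist activity at Orexin/Hypocretin receptor type 1 (Homo sapiens), read by FLIPR and calcium flux; a higher number here means a weaker inhibitor, a lower number a stronger inhibitor:
compound 1 `CCc1nc(Cl)c2n1CCN([C@@H](C(=O)NC)c1ccccc1)[C@H]2CCc1cccc(C(F)(F)F)c1`: 72 nM
compound 2 `CCc1nc(Cl)c2n1CCN([C@@H](C(=O)NC)c1ccccc1)[C@H]2CCc1ccc(C(F)(F)F)c(Cl)c1`: 20 nM
compound 3 `CCc1nc(Cl)c2n1CCN([C@@H](C(=O)NC)c1ccccc1)[C@H]2CCc1ccc(C(F)(F)F)cc1F`: 45 nM

Compound 2 has the lowest number of the three in this assay; compound 3 stands nearest and compound 1 furthest, both steps beyond the scatter. Compound 4 `CCc1nc(Cl)c2n1CCN([C@@H](C(=O)NC)c1ccccc1)[C@H]2CCc1ccc(F)c(F)c1F` differs from compound 2 in one place: 2,3,4-trifluorophenyl in place of 3-chloro-4-(trifluoromethyl)phenyl on a saturated chain carbon, two bonds along the chain from a saturated ring carbon. Going by the values given here, two measured steps bear on changes of this ring: a 3.6-fold lower number from compound 1 to compound 2 (0.56 log units; beyond the scatter) and a 2.3-fold higher number from compound 2 to compound 3 (0.35 log units; beyond the scatter). Both are modest and both keep a trifluoromethyl on the ring, which compound 4 lacks, so neither tests the change directly. Since each rearrangement of the ring substituents so far moved the number beyond the scatter, and compound 2 holds the lowest value, a modest rise is expected, a 3.0-fold higher number from compound 2 to compound 4 (0.48 log units; beyond the scatter). Compound 4 is estimated at 60 nM, with a range from 20 nM to 180 nM.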

Compound 4, half-maximal inhibitory concentration: 30 nM
Compound 4: middle estimate off by 2.0-fold (0.30 log units), on the high side; low and high end bracket the measured number.
By their numbers in this assay, from the lowest: compounds 2, 4, 3 and 1 (each within the scatter of the next, the first and the last beyond it).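

In this assay a trifluoromethyl on this ring is not required: with a 1.5-fold higher number from compound 2 to compound 4 (0.18 log units; within the scatter) and a 1.5-fold lower number from compound 3 to compound 4 (0.18 log units; within the scatter), the 2,3,4-trifluorophenyl ring stands level with the 3-chloro-4-(trifluoromethyl)phenyl and 2-fluoro-4-(trifluoromethyl)phenyl rings. Only a 2.4-fold lower number from compound 1 to compound 4 (0.38 log units; beyond the scatter) separates it from a trifluoromethyl-bearing ring, that of compound 1. No measured evidence accounts for these steps.

Still open, as far as these compounds go, is whether a ring carrying an amine or a carboxylic acid, or a longer chain leading to the ring, would keep the number at this level.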